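Fluoro for methyl on the aryl ring: cytotoxicity note

A few compounds are considered here, and "the series" means these few. Any claim that something is new, unique, unknown or untested is made for them only; others in the source may bear on it.

Two compounds of the series carry a reading in a functional assay on C6 cells (Rattus norvegicus) for cytotoxicity, read by MTT assay, with a stated time of 24 h, tested at 100 ug/mL; on this read-out lower numbers stand for a stronger effect and higher numbers for a weaker effect at the one concentration tested. Compound 1 `Cc1ccc(-c2cs/c(=N/NC(=O)CSc3nnnn3-c3ccccc3)n2-c2ccccc2)cc1` gives 28.5% in this assay. Compound 2 `Cn1cnnc1SCC(=O)N/N=c1/scc(-c2ccc(C#N)cc2)n1-c1ccccc1` gives 55.2% in this assay. Among these two numbers compound 1 stands lowest; the nearest is compound 2, whose number lies higher by a margin beyond the scatter, so compound 1 shows the stronger effect of the pair. Within the data shown here, compound 2 differs from compound 1 in more than one place, so the two values are a comparison only and define no single step.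

Compound 3 `O=C(CSc1nnnn1-c1ccccc1)N/N=c1/scc(-c2ccc(F)cc2)n1-c1ccccc1` is still to be measured in this assay. Against compound 1 its difference is fluoro in place of methyl on an aromatic carbon. Among the measured compounds shown here, no step between measured compounds isolates a change of this kind, so no measured size is available to guide the expectation. The change is small in count and leaves the rest of compound 1 untouched, and a modest step is expected, possibly none beyond the scatter. The step from compound 1 to compound 3 is estimated as a number 4.5 percentage points higher from compound 1 to compound 3 (within the scatter). For compound 3 the expected value in this assay is 33%, with a range from 18% to 50%.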

Compound 3, a percentage reported as activity, at one concentration (the size of the read-out at that concentration, not a potency): 35.8%
Beside the measured number, compound 3's estimate is 2.8 percentage points below it; low and high end bracket the measured number.
By their numbers in this assay, from the lowest: compounds 1 and 3 (each within the scatter of the next); then compound 2.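

In this assay, the exchange of 4-methylphenyl for 4-fluorophenyl gives a number 7.3 percentage points higher from compound 1 to compound 3 (within the scatter). Among these compounds, this is the first step that changes one place only, so this position now has a measured step, where the earlier pair offered only a comparison across several differences. On this aromatic carbon, para to a large group, methyl and fluoro cannot be told apart in this read-out at the one concentration tested, so the methyl group of compound 1 is not shown to be required for its reading, and no supporting measurement bears on the result.

On these data alone, one exchange does not show how much change this position tolerates, and whether an amine, a carboxylic acid or a longer alkyl chain at the same place would keep the reading remains open. Also open, as far as these compounds go, is whether fluoro in place of methyl would read the same way on a compound whose remaining structure differs from that of compound 1, as that of compound 2 does.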